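Methyl in place of nitro: from compound 1 to compound 4

A few compounds are considered here, and "the series" means these few. Any claim that something is new, unique, unknown or untested is made for them only; others in the source may bear on it.

Three compounds share a bridged diamine attached to a pyridine that carries an arylamino group, and all three were measured in an assay on cell membranes for displacement of a labelled ligand from Neuronal acetylcholine receptor; alpha4/beta2 (Rattus norvegicus); on this read-out lower numbers stand for stronger inhibition and higher numbers for weaker inhibition. Compound 1 `O=[N+]([O-])c1ccc(Nc2ccc(N3CC4CC(C3)N4)cn2)cc1` gives 1.76 nM, the highest of the three numbers. Compound 2 `Clc1ccc(Nc2cncc(N3CC4CC(C3)N4)c2)cc1Cl` gives 1.25 nM, which lies within the usual scatter of the value of compound 1. Compound 3 `O=[N+]([O-])c1ccc(Nc2cncc(N3CC4CC(C3)N4)c2)cc1` gives 0.0225 nM, far below the other two and well beyond the scatter. For the measured compounds named here, compound 2 and compound 3 differ from each other at more than one place, so their two values can only be set side by side; no pair in the set differs at a single point.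

Compound 4 `Cc1ccc(Nc2ccc(N3CC4CC(C3)N4)cn2)cc1` is derived from compound 1 by methyl in place of nitro on an aromatic carbon. Going by the values given here, no measured pair shows this exchange, so the expectation rests on compound 1 alone. The account expects the change to weaken binding by a moderate step, beyond the scatter, because the lowest value in the set belongs to compound 3 with 0.0225 nM, which also carries the nitro group. For compound 4 the expected step is an 8.5-fold higher number from compound 1 to compound 4 (0.93 log units; beyond the scatter). Compound 4 is therefore estimated at 15 nM, with a range from 3 nM to 80 nM.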

Compound 4, inhibition constant: 52.1 nM
The estimate for compound 4 lay 3.5-fold (0.54 log units) below the measured number, and the stated range covers the measured number.
By their numbers in this assay, from the lowest: compound 3; then compounds 2 and 1 (each within the scatter of the next); then compound 4.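

In this assay, for the compounds shown here, methyl in place of nitro on an aromatic carbon gives a 30-fold higher number from compound 1 to compound 4 (1.47 log units; beyond the scatter), the first step in the set between two compounds that differ in one place only, and it is a large one. Until now the nitro group could only be set beside values from compounds that differ at more than one place, whereas this pair isolates the exchange at a single carbon of the six-membered aromatic ring of carbon only, para to a large group, and shows that binding on this core depends strongly on what sits there. No measurement in hand explains why the step is this large, so the pair records its size and direction but not its origin.

On the core of compound 1 the compounds shown hold only nitro and methyl at this place, so it remains open where an amine, a carboxylic acid or a nitrile on the same carbon would fall relative to compound 1 and compound 4. From the compounds shown here alone, it is also open whether the same exchange on the core of compound 3 would give a step of similar size, since that core appears here only with the nitro group.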